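Adding heptyloxy to compound 1: what to expect

The source may report more compounds than this note shows. Statements on the series, on what has been measured and on what is new or still open speak of the compounds shown alone.

Compound 1 `O=C1OC[C@H](Cc2ccccc2)[C@H]1Cc1ccccc1`: 77000 nM
Compound 2 `COc1ccccc1C[C@H]1C(=O)OC[C@@H]1Cc1ccccc1`: 79000 nM
Compound 3 `O=C1OC[C@H](Cc2ccccc2)[C@H]1Cc1ccccc1C(F)(F)F`: 37000 nM

These three numbers come from a functional assay on HL-60 cells (Homo sapiens) for cytotoxicity, read by WST assay, with a stated time of 48 h; on this read-out higher numbers stand for an effect only at larger amounts of compound and lower numbers for an effect already at smaller amounts. Compound 1 and compound 2 sit together at the upper end of this small set, while compound 3 has the lowest number. Compound 1 is therefore a reasonable reference point, with one measured neighbour level with it and one clearly lower.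

Compound 4 `CCCCCCCOc1cccc(C[C@H]2C(=O)OC[C@@H]2Cc2ccccc2)c1` keeps the core of compound 1 but has heptyloxy in place of hydrogen on an aromatic carbon, meta to a large group: heptyloxy in place of hydrogen on an aromatic carbon.

Two measured changes also replace hydrogen on an aromatic carbon. Methoxy gave a 1.0-fold higher number from compound 1 to compound 2 (0.01 log units; within the scatter), and trifluoromethyl gave a 2.1-fold lower number from compound 1 to compound 3 (0.32 log units; beyond the scatter). Only the trifluoromethyl step lies beyond the scatter, and it is modest. Going by the values given here, no measured compound carries a chain like heptyloxy, so these steps offer only a weak guide. Even so, the one step beyond the scatter points downward, so a lower number is expected in this assay, of modest size or somewhat larger. The expected change is a 4.3-fold lower number from compound 1 to compound 4 (0.63 log units; beyond the scatter). For compound 4 the estimated value is 18000 nM, with an expected range from 5000 nM to 60000 nM.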

Compound 4, half-maximal effective concentration: 81000 nM
Estimate against measurement, compound 4: 4.5-fold (0.65 log units) below, outside the stated range (above it).
By their numbers in this assay, from the lowest: compound 3; then compounds 1, 2 and 4 (each within the scatter of the next).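

In this assay, going by these compounds alone, adding heptyloxy gives a 1.1-fold higher number from compound 1 to compound 4 (0.02 log units; within the scatter), so a chain much longer than any group on the earlier compounds leaves the number where it was. This is new information about this place, on an aromatic carbon meta to a large group: a group of 8 heavy atoms can be added to the core of compound 1 with no change that stands out from the scatter. Adding more atoms therefore does not by itself lower the number here, as the trifluoromethyl step, a 2.1-fold lower number from compound 1 to compound 3 (0.32 log units; beyond the scatter), might have suggested, and nothing available explains why heptyloxy and trifluoromethyl differ in this way.

The compounds shown leave open whether this flat result belongs to heptyloxy alone or holds for other groups at this place, such as a shorter propyloxy chain or a chain ending in an amine or a carboxylic acid. They also leave open whether heptyloxy would give the same result at another carbon of the ring, and whether trifluoromethyl at this place would match the step seen with compound 3.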